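Hydroxy for hydrogen across two cores

The compounds below may be only part of what the source reports. "The series", "measured", "known", "first", "only" and "open" are said of these compounds alone.

The series is read in a functional assay on HepG2 cells (Homo sapiens) for antiproliferative activity, read by fluorescence and resazurin assay, with a stated time of 48 h; a higher number here means a weaker inhibitor, a lower number a stronger inhibitor. Compound 2 `O=C(N/N=C/c1cccnc1)c1cc2ccccc2oc1=O` gives 15900 nM. Compound 1 `O=C(N/N=C/c1cccnc1)c1cc2ccc(O)cc2oc1=O` carries the change hydroxy in place of hydrogen on an aromatic carbon on the core of compound 2. In this assay compound 1 gives 18400 nM. The step of a 1.2-fold higher number from compound 2 to compound 1 (0.06 log units; within the scatter) is therefore small. Compound 3 `CCOc1ccc2nc(Cl)c(/C=N/NC(=O)c3cc4ccccc4oc3=O)cc2c1` has a different core; the difference between the core of compound 2 and the core of compound 3 is not broken down here. In this assay compound 3 gives 33100 nM, a number separated from that of compound 2 by a margin beyond the scatter, while against compound 1 the gap stays within it.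

Compound 4 `CCOc1ccc2nc(Cl)c(/C=N/NC(=O)c3cc4ccc(O)cc4oc3=O)cc2c1` is not yet measured. It stands to compound 3 as compound 1 stands to compound 2: the change (hydroxy in place of hydrogen on an aromatic carbon), made at a place described in the same words on both cores, so it is the same change. For the measured compounds named here, the one measured instance of it, a 1.2-fold higher number from compound 2 to compound 1 (0.06 log units; within the scatter), stayed within the scatter, and the expectation for compound 4 in this assay rests on that single step and on the value of compound 3, 33100 nM. The expected step of a 1.2-fold higher number from compound 3 to compound 4 (0.08 log units; within the scatter) is small. Compound 4 is estimated at 40000 nM, with a range from 20000 nM to 80000 nM. Whether the second core carries the change in the same way remains to be seen.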

Compound 4, half-maximal inhibitory concentration: 19200 nM
Beside the measured number, compound 4's estimate is 2.1-fold (0.32 log units) above it, and the stated range ends above it.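

With hydroxy in place of hydrogen on an aromatic carbon, the second core gives a 1.7-fold lower number from compound 3 to compound 4 (0.24 log units; within the scatter) in this assay, so the step on this core, like the one on the first, stays within the scatter. The two instances do not differ beyond what two such steps would show by scatter alone, and in this series the change carries from one core to the other as a step too small to read: the same change on two cores in this assay, a 1.2-fold higher number (0.06 log units; within the scatter) from compound 2 to compound 1 and a 1.7-fold lower number (0.24 log units; within the scatter) from compound 3 to compound 4, 2.0-fold (0.30 log units) apart, within the scatter of two such steps. This does not show that the change is without any effect on either core, nor that it would behave the same way on a third core, and no direction can be read from either step, even though the two are printed with opposite signs.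

The compounds shown leave open whether another group at the same place, such as methoxy, an amine or a carboxylic acid, would give a step beyond the scatter on either core. Also open, on these data alone, are how the two cores themselves compare, since their difference is not broken down here, and whether the reading holds outside this assay.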